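Trading a bromine for a second fluorine on the benzyl group

The source may report more compounds than this note shows. Statements on the series, on what has been measured and on what is new or still open speak of the compounds shown alone.

Compound 1 `COc1ccc2[nH]c3c(c2c1)CCNC31CCN(Cc2ccc(Br)c(F)c2)CC1` carries a 4-bromo-3-fluorophenyl on a saturated chain carbon bound to an amine nitrogen in a ring, and in an assay on FRT cells for positive allosteric modulation of Cystic fibrosis transmembrane conductance regulator variant N1303K (Homo sapiens), in the presence of a further agent that is not named here (a higher number here means that more compound is needed for the effect, a lower number that less compound is needed), compound 1 gives 1800 nM. Among the three measured compounds this is the lowest number: compound 3 `COc1ccc2[nH]c3c(c2c1)CCNC31CCN(Cc2c(F)c(F)c(F)c(F)c2F)CC1`, which bears a 2,3,4,5,6-pentafluorophenyl at the same place, gives 2100 nM and lies within the scatter of compound 1, while compound 2 `COc1ccc2[nH]c3c(c2c1)CCNC31CCN(Cc2ccc(F)c(Cl)c2F)CC1` gives 4500 nM, and the step of a 2.5-fold higher number from compound 1 to compound 2 (0.40 log units; beyond the scatter) is the one change beyond the scatter in this set.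

Compound 4 `COc1ccc2[nH]c3c(c2c1)CCNC31CCN(Cc2cccc(F)c2F)CC1` differs from compound 1 at the same place: 2,3-difluorophenyl in place of 4-bromo-3-fluorophenyl on a saturated chain carbon bound to an amine nitrogen in a ring. The bromine leaves and a second fluorine enters, so the group that enters holds 6 carbon and 2 fluorine heavy atoms against the 6 carbon, 1 fluorine and 1 bromine of the group that leaves. The step from compound 1 to compound 2, also an exchange of this group with a chlorine kept and fluorines added, raised the number modestly, whereas the exchange to compound 3 changed nothing beyond the scatter. Taken together, these steps point to a small rise in this assay for compound 4, expected as a 1.7-fold higher number from compound 1 to compound 4 (0.22 log units; within the scatter), though a result within the scatter of compound 1 would not surprise. Compound 4 is therefore estimated at 3000 nM, with a range from 1200 nM to 8000 nM.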

Compound 4, half-maximal effective concentration: 13600 nM
For compound 4 the middle estimate is 4.5-fold (0.66 log units) below the measured one, and the stated range ends below it.
By their numbers in this assay, from the lowest: compounds 1 and 3 (each within the scatter of the next); then compound 2; then compound 4.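

In this assay, 2,3-difluorophenyl in place of 4-bromo-3-fluorophenyl gives a 7.6-fold higher number from compound 1 to compound 4 (0.88 log units; beyond the scatter), the largest step seen so far at this place, even though the two groups hold the same count of heavy atoms, so that count alone does not set the number. The change from the 3-chloro-2,4-difluorophenyl group also raises the number, with a 3.0-fold higher number from compound 2 to compound 4 (0.48 log units; beyond the scatter), so 2,3-difluorophenyl gives the highest number of the four, yet a ring carrying fluorine alone need not do so, as compound 3 gives 2100 nM. No measurement is available here that would explain the size of these steps.

Compound 4 loses the bromine and gains a fluorine in a single change, so the compounds shown cannot tell how much of the rise goes with each part, and a 4-bromophenyl or a 4-bromo-2,3-difluorophenyl group would separate the two. From the compounds shown here alone, it also remains open whether a group without halogen at this place, such as an unsubstituted phenyl, a methoxyphenyl or a pyridine ring, would fall closer to compound 1 or to compound 4.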